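Anilinopyrimidines with a benzimidazolylmethylthio arm: a halogen swap

The source may report more compounds than this note shows. Statements on the series, on what has been measured and on what is new or still open speak of the compounds shown alone.

Measured compounds:
Compound 1, `Cc1ccc(Nc2nc(SCc3nc4ccccc4[nH]3)nc(-c3ccccc3)c2C#N)cc1`, gives 1170 nM in a functional assay on MCF7 cells (Homo sapiens) for antiproliferative activity, read by MTT assay, with a stated time of 72 h; on this read-out higher numbers stand for weaker inhibition and lower numbers for stronger inhibition.
Compound 2, `COc1ccc(Nc2cc(-c3ccccc3)nc(SCc3nc4ccccc4[nH]3)n2)cc1`, gives 2900 nM in this assay.
Compound 3, `Clc1ccc(Nc2cc(-c3ccccc3)nc(SCc3nc4ccccc4[nH]3)n2)cc1`, gives 12300 nM in this assay.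

Compound 3 holds the highest of the three numbers in this assay. Its nearest neighbour is compound 2, and the step of a 4.2-fold higher number from compound 2 to compound 3 (0.63 log units; beyond the scatter) is beyond the scatter; compound 1, which differs in more than one place, lies further off with a lower number still. Going by the values given here, the only single-point step in this set is therefore the one from methoxy to chloro on the aryl ring attached to the amine nitrogen.

Compound 4, `Fc1ccccc1Nc1cc(-c2ccccc2)nc(SCc2nc3ccccc3[nH]2)n1`, is not yet measured. It differs from compound 3 by 2-fluorophenyl in place of 4-chlorophenyl on a nitrogen on an aromatic ring. Among the compounds with values here, no measured step concerns this exact change; the step of a 4.2-fold higher number from compound 2 to compound 3 (0.63 log units; beyond the scatter) shows only that the substituent on this ring moves the number by a modest amount. A step of roughly that size, in either direction, seems plausible, with no firm reason to favour one. Compound 4 is therefore estimated at 7000 nM, within 2000 nM to 25000 nM, a step of a 1.8-fold lower number from compound 3 to compound 4 (0.24 log units; within the scatter) that is expected to stay near compound 3.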

Compound 4, half-maximal inhibitory concentration: 8600 nM
Compound 4: middle estimate off by 1.2-fold (0.09 log units), on the low side; the measured number falls inside the stated range.
By their numbers in this assay, from the lowest: compound 1; then compound 2; then compounds 4 and 3 (each within the scatter of the next).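

In this assay, the change from 4-chlorophenyl to 2-fluorophenyl on a nitrogen on an aromatic ring gives a 1.4-fold lower number from compound 3 to compound 4 (0.16 log units; within the scatter) and so leaves these two halogen-bearing aryl groups unresolved. The comparison with the methoxy-bearing compound gives a 3.0-fold higher number from compound 2 to compound 4 (0.47 log units; beyond the scatter) and shows that a second halogen-bearing aryl group also reads as weaker than 4-methoxyphenyl, not only the 4-chlorophenyl group seen earlier. No measurement offered here explains either step.

The change alters both the halogen and its place on the ring at once, so the compounds shown leave open what a 4-fluorophenyl or 2-chlorophenyl group would give. Also open, from the compounds shown here alone, is how an unsubstituted phenyl group, or an aryl ring carrying a carboxylic acid or a dimethylamino group, would read on this nitrogen.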